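Swapping dimethylamino for fluoro on the alkyne aryl

The compounds below may be only part of what the source reports. "The series", "measured", "known", "first", "only" and "open" are said of these compounds alone.

Compounds measured so far in a functional assay on MCF7 cells (Homo sapiens) for inhibition, read by sulforhodamine B assay, with a stated time of 48 h; on this read-out lower numbers stand for stronger inhibition of growth and higher numbers for weaker inhibition of growth:
Compound 1, `COC(=O)c1sc2cc(C#Cc3cccnc3)cnc2c1N`, gives > 150000 nM, which is a limit of the assay and not a number.
Compound 2, `COC(=O)c1sc2cc(C#Cc3ccc(N(C)C)cc3)cnc2c1N`, gives 20600 nM.

Among the measured compounds shown here, compound 2 thus holds the only numerical value in this set; the remaining entry is the limit of > 150000 nM in this assay, at which 1 of the 2 values shown sits, so there is no second number against which compound 2 can be ordered.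

Compound 3, `COC(=O)c1sc2cc(C#Cc3ccc(F)cc3)cnc2c1N`, has not yet been measured. It differs from compound 2 by fluoro in place of dimethylamino on an aromatic carbon. For the measured compounds named here, no measured pair in this set shows a change of this kind, so the size of the step cannot be read from the data and has to be estimated. The account expects a step toward weaker inhibition of growth, a 2.9-fold higher number from compound 2 to compound 3 (0.46 log units; beyond the scatter), beyond the usual scatter but short of a return to the limit. Compound 3 is therefore expected to give about 60000 nM in this assay, with a likely range from 15000 nM to 250000 nM.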

Compound 3, concentration for 50% growth inhibition: 29000 nM
Compound 3: the middle estimate sits 2.1-fold (0.32 log units) above what was measured; the measured number falls inside the stated range.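

In this assay, the exchange of dimethylamino for fluoro on an aromatic carbon of the six-membered aromatic ring of carbon only comes to a 1.4-fold higher number from compound 2 to compound 3 (0.15 log units; within the scatter), so this read-out does not separate the two groups at this position, although they differ in size and in hydrogen-bond acceptors. Among the compounds shown here, the first comparison to reach the aryl group at the end of the alkyne itself, 4-fluorophenyl in place of pyridin-3-yl on a triple-bonded carbon, gives an at least 5.1-fold lower number from compound 1 to compound 3 (0.71 log units; beyond the scatter), which shows that the identity of this ring matters more here than the exchange on it. That step is a bound and not an exact size, because compound 1 rests on a limit of the assay and not on a number: the limit of > 150000 nM in this assay, at which 1 of the 3 values shown sits.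

The compounds shown leave open whether a methoxy, a trifluoromethyl or a primary amine on the same aromatic carbon would also stay level with fluoro and dimethylamino, or whether an unsubstituted phenyl would already do as well. They also say nothing about a carboxylic acid or an amide in place of the methyl ester on the shared core.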